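Swapping Butyl for Cyclohexyl on a Hydrazide Nitrogen

A few compounds are considered here, and "the series" means these few. Any claim that something is new, unique, unknown or untested is made for them only; others in the source may bear on it.

Compound 1 `CCc1ccc(C(=O)NN(C(=O)C2CC=CCC2)C(C)(C)C)cc1`: 1000 nM
Compound 2 `CCCCN(NC(=O)c1ccccc1)C(=O)c1ccccc1`: 7080 nM

In an assay on cells for agonist activity at ecdysone receptor (Bombyx mori), read by a luciferase reporter, with a stated time of 24 h (on this read-out higher numbers stand for an effect only at larger amounts of compound and lower numbers for an effect already at smaller amounts), compound 2 stands at the higher of the two numbers, and its gap to compound 1 lies beyond the usual scatter. Compound 3 `O=C(NN(C(=O)c1ccccc1)C1CCCCC1)c1ccccc1` differs from compound 2 by cyclohexyl in place of butyl on an amide-type nitrogen. Among the compounds with values here, no measured pair shows this exact change, so the expectation rests on the two values alone. A moderate downward step is expected, because compound 1, which also carries a ring, gives 1000 nM. The estimated step of a 2.4-fold lower number from compound 2 to compound 3 (0.37 log units; beyond the scatter) is therefore expected to go toward smaller amounts. Compound 3 is expected to give about 3000 nM, within 700 nM to 15000 nM.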

Compound 3, half-maximal effective concentration: 891 nM
Beside the measured number, compound 3's estimate is 3.4-fold (0.53 log units) above it; low and high end bracket the measured number.
By their numbers in this assay, from the lowest: compounds 3 and 1 (each within the scatter of the next); then compound 2.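

In this assay cyclohexyl in place of butyl on an amide-type nitrogen gives a 7.9-fold lower number from compound 2 to compound 3 (0.90 log units; beyond the scatter) and so shows that the number responds to the group at this position. The entering group brings one six-membered non-aromatic ring of carbon only and no hydrogen-bond donors or acceptors. No measurement shown gives a cause for this step. From the compounds shown here alone, whether the ring or the larger count of carbon atoms matters stays open. A hexyl chain or a phenyl ring on this nitrogen would help separate the two.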